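Oxygen-linked ethyl carboxyphenyl arm in a bile acid receptor series

The compounds below may be only part of what the source reports. "The series", "measured", "known", "first", "only" and "open" are said of these compounds alone.

Compound 3 `O=C(O)c1cccc(OCc2ccc(OCc3c(-c4c(Cl)cccc4Cl)noc3C3CC3)nc2C(F)(F)F)c1` gives 62% in a functional assay on HEK293 cells for agonist activity at Bile acid receptor (Homo sapiens); a lower number here means a smaller maximal response, a higher number a larger maximal response. Its companions compound 1 `CC(Nc1ccc(C(=O)O)cc1)c1ccc(OCc2c(-c3c(Cl)cccc3Cl)noc2C2CC2)nc1C(F)(F)F` with 59% and compound 2 `CC(c1ccc(OCc2c(-c3c(Cl)cccc3Cl)noc2C2CC2)nc1C(F)(F)F)N(C)c1ccc(C(=O)O)cc1` with 55% sit close by. The step of a number 3 percentage points higher from compound 1 to compound 3 (within the scatter) falls within the scatter. The gap between compound 2 and compound 3 also falls within the scatter. Compound 4 `CC(Oc1ccc(C(=O)O)cc1)c1ccc(OCc2c(-c3c(Cl)cccc3Cl)noc2C2CC2)nc1C(F)(F)F` carries 1-(4-carboxyphenoxy)ethyl in place of (3-carboxyphenoxy)methyl on an aromatic carbon. Among the compounds with values here, two measured steps bear on this: a number 3 percentage points higher from compound 1 to compound 3 (within the scatter), which swapped the linker and carboxyphenyl arm, and a number 4 percentage points lower from compound 1 to compound 2 (within the scatter), which altered the linker atom. Neither moved the efficacy beyond the scatter, so no step beyond the scatter is expected for a number 4 percentage points lower from compound 3 to compound 4 (within the scatter). Compound 4 is therefore estimated at 58%, with a range from 46% to 70%.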

Compound 4, largest response reached (reported as efficacy), in percent of the reference or control that the assay uses: 70%
Beside the measured number, compound 4's estimate is 12 percentage points below it; the measured number falls inside the stated range.
By their numbers in this assay, from the lowest: compounds 2, 1, 3 and 4 (each within the scatter of the next, the first and the last beyond it).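

In this assay, within the data shown here, 4-carboxyphenoxy on the saturated chain carbon gives a number 11 percentage points higher from compound 1 to compound 4 (beyond the scatter) and a number 15 percentage points higher from compound 2 to compound 4 (beyond the scatter), the first steps in this set to leave the scatter, so the atom linking the arm matters here. Against the unbranched arm, the step is a number 8 percentage points higher from compound 3 to compound 4 (within the scatter) and does not separate the two oxygen-linked compounds. Nothing available explains the effect of the linking atom. That step from compound 3 alters both the chain and the carboxy position, leaving their separate contributions unresolved. As far as these compounds go, a sulfur linker or a tetrazole in place of the carboxylic acid remains open.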